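Replacing ethynyl with 4-cyanophenyl on the benzoxaborole amide

This account rests on a few compounds, and the source may have more. Where it says the series, first, only, none or still open, it means among the compounds named here.

Compound 1 `C#Cc1cccc(NC(=O)CCc2cccc3c2B(O)OC3)c1` gives 980 nM in a functional assay on SK-OV-3 cells (Homo sapiens) for antiproliferative activity, read by MTT assay, with a stated time of 72 h (a higher number here means a weaker inhibitor, a lower number a stronger inhibitor), the lowest of the two numbers available. Among the compounds with values here, compound 2 `O=C(CCc1cccc2c1B(O)OC2)Nc1ccccc1-c1ccccc1` gives 26000 nM in this assay, a gap beyond the scatter, though no single-point step links the two. Compound 3 `N#Cc1ccc(-c2cccc(NC(=O)CCc3cccc4c3B(O)OC4)c2)cc1` carries 4-cyanophenyl in place of ethynyl on an aromatic carbon. Within the data shown here, with no measured step to guide the size, the change is expected to cost a modest amount of potency, as compound 2 with 26000 nM is the only other aryl-bearing analogue and it is weak. For compound 3 the expected step is a 2.6-fold higher number from compound 1 to compound 3 (0.41 log units; beyond the scatter), giving an estimate of 2500 nM, within 700 nM to 9000 nM.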

Compound 3, half-maximal inhibitory concentration: 340 nM
Beside the measured number, compound 3's estimate is 7.4-fold (0.87 log units) above it; the measured number lies below the stated range.
By their numbers in this assay, from the lowest: compound 3; then compound 1; then compound 2.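

In this assay the change from ethynyl to 4-cyanophenyl brings a 2.9-fold lower number from compound 1 to compound 3 (0.46 log units; beyond the scatter) and so shows that this aromatic carbon accepts a much larger ring-bearing group with a modest gain in potency. Ethynyl is therefore not required at this position for activity in these cells, and the added aromatic ring and nitrile are at least compatible with it. Still open, as far as these compounds go, is how a carboxylic acid or an amine at this position would compare with 4-cyanophenyl. No evidence bears on the cause of this step.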